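Working notes on an aryl swap in the shared core

A few compounds are considered here, and "the series" means these few. Any claim that something is new, unique, unknown or untested is made for them only; others in the source may bear on it.

The series is followed in an in vitro functional assay on HEK285-7 cells for antagonist activity at prostaglandin D2 receptor 2 (Homo sapiens), read by BRET and beta-arrestin recruitment; a lower number here means a smaller maximal response, a higher number a larger maximal response. Compound 1 `O=C(O)Cc1sc(C(c2ccc(F)cc2)c2ccc(F)cc2)nc1-c1ccnc(N2CCC2)c1` gives 80%. Compound 2 `O=C(O)Cc1sc(C(c2ccccc2)c2ccccc2)nc1-c1ccc(F)c(F)c1` gives 80%, and compound 3 `COc1ccc(C(c2ccccc2)c2nc(-c3ccc(Cl)cc3)c(CC(=O)O)s2)cc1` gives 80%. On these numbers compound 1 stands level with compound 2 and compound 3 at the digits shown; the nearest is compound 2 and the furthest is compound 3, and in both pairs there is no change beyond the scatter. Among the compounds with values here, no pair of measured compounds that differ in one place is available, so the series offers no calibrated step.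

Compound 4 `CS(=O)(=O)Nc1cccc(-c2nc(C(c3ccc(F)cc3)c3ccc(F)cc3)sc2CC(=O)O)c1` has not been measured in this assay. It differs from compound 1 in one place: 3-(methanesulfonamido)phenyl in place of 2-(azetidin-1-yl)pyridin-4-yl on an aromatic carbon. Compound 2 and compound 3 carry other groups at this place of the shared core and sit level with compound 1, so within these three compounds a change of the group there has not moved the maximal response beyond the scatter. The expected step is no change at the digits printed from compound 1 to compound 4 (within the scatter), which is none beyond the scatter. For compound 4 the estimate is 80%, with a range from 65% to 95%.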

Compound 4, largest response reached (reported as efficacy), in percent of the reference or control that the assay uses: 80%
Beside the measured number, compound 4's estimate shows no gap at the digits printed; the measured number falls inside the stated range.
By their numbers in this assay, from the lowest: compounds 1, 2, 3 and 4 (each within the scatter of the next).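

In this assay, within the data shown here, the step reads no change at the digits printed from compound 1 to compound 4 (within the scatter) for 3-(methanesulfonamido)phenyl in place of 2-(azetidin-1-yl)pyridin-4-yl, the first comparison that differs in one place only. Compound 2 and compound 3 differ from compound 1 in more than one place, whereas here the rest of the shared core is held fixed, so the level reading belongs to this position alone and holds across a swap from a ring with a hetero atom to a carbon-only ring that brings a hydrogen-bond donor. Nothing shown explains why the maximal response stays level.

As far as these compounds go, each group compared at this place has a six-membered aromatic ring joined to the shared core, so a morpholine or a primary amine there remains open. Also open, from the compounds shown here alone, is whether a longer chain in place of the carboxymethyl group would move the response.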